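Para substituent swap on the aryl ring of the shared core

This account rests on a few compounds, and the source may have more. Where it says the series, first, only, none or still open, it means among the compounds named here.

Two compounds of this series have been run in a functional assay on CHO cells for antagonist activity at corticotropin-releasing factor receptor 1 (Homo sapiens), read by cAMP accumulation; on this read-out lower numbers stand for stronger inhibition and higher numbers for weaker inhibition. Compound 1 `Cc1nc(NC(C2CC2)C2CC2)c2nc(C)n(-c3ccc(C#N)cc3)c2n1` gives 62 nM. Compound 2 `Cc1nc(NC(C2CC2)C2CC2)c2nc(C)n(-c3ccc(Cl)cc3)c2n1` gives 11 nM, the lowest of the two numbers; the change from compound 1 to compound 2 a 5.6-fold lower number from compound 1 to compound 2 (0.75 log units; beyond the scatter) is a chloro in place of cyano on an aromatic carbon, a modest step beyond the scatter.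

Compound 3 `CCOc1ccc(-n2c(C)nc3c(NC(C4CC4)C4CC4)nc(C)nc32)cc1` is not yet measured. Its difference from compound 2 is ethoxy in place of chloro on an aromatic carbon, that is, an ethoxy in place of chloro on an aromatic carbon, para to a large group. Among the measured compounds shown here, only one measured step bears on this position, that from compound 1 to compound 2, and it shows that a change of the para group can move the number well beyond the scatter. That step does not involve ethoxy, so it gives direction only weakly. The expected outcome for compound 3 is a small step from compound 2 toward a higher number, a 1.8-fold higher number from compound 2 to compound 3 (0.26 log units; within the scatter), within or near the scatter. Compound 3 is therefore estimated at 20 nM, with a range from 5 nM to 80 nM.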

Compound 3, inhibition constant: 20 nM
Compound 3: middle estimate and measured number agree at the digits printed; low and high end bracket the measured number.
By their numbers in this assay, from the lowest: compounds 2 and 3 (each within the scatter of the next); then compound 1.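

In this assay, the position on the aromatic carbon para to a large group accepts ethoxy about as well as chloro: a 1.8-fold higher number from compound 2 to compound 3 (0.26 log units; within the scatter), even though ethoxy brings 3 heavy atoms and a hydrogen-bond acceptor where chloro has 1 heavy atom and no acceptor. The comparison with the nitrile gives a 3.1-fold lower number from compound 1 to compound 3 (0.49 log units; beyond the scatter), which, read with a 5.6-fold lower number from compound 1 to compound 2 (0.75 log units; beyond the scatter), leaves compound 1 as the one set apart, with both chloro and ethoxy beyond the scatter from cyano and within the scatter of each other. No measured property of these groups is available to account for these steps.

The compounds shown do not tell whether this tolerance extends to a longer chain such as butoxy, to an amine such as dimethylamino, or to a carboxylic acid at the same carbon. As far as these compounds go, all three also share the rest of the core unchanged, so it remains open whether the same steps would hold if the two cyclopropyl groups on the amine were replaced by isopropyl groups.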